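The source may report more compounds than this note shows. Statements on the series, on what has been measured and on what is new or still open speak of the compounds shown alone.

Compound 1 `O=C(CN1CCN(c2ccc(F)cc2)CC1)Nc1nc2c(s1)CCCC2` and compound 2 `O=C(CN1CCN(c2ccc(F)cn2)CC1)Nc1nc2c(o1)CCCC2` share a core and a ring-bound amine, and both have been run in a physicochemical assay for lipophilicity, in phosphate buffer, measured as octanol-water partition, at pH 7.4; a lower number here means a more polar compound, a higher number a more lipophilic compound. Compound 1 gives 4.5, the higher of the two numbers. Compound 2 gives 2.7, which lies well beyond the scatter below compound 1; the two structures differ in more than one place, so the gap is not tied to a single change. Compound 3 `O=C(CN1CCN(c2ccncc2)CC1)Nc1nc2c(s1)CCCC2` has not yet been measured. Against compound 1 it shows one change: pyridin-4-yl in place of 4-fluorophenyl on an amine nitrogen in a ring. With a fluorine-bearing all-carbon ring giving way to a ring with one nitrogen, a drop in this assay is expected for compound 3, likely a clear step beyond the scatter. Starting from compound 1 at 4.5, the expected step is a number 1.90 log units lower from compound 1 to compound 3 (beyond the scatter). Compound 3 is therefore estimated at 2.6, within a range from 1.9 to 3.3.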

Compound 3, distribution coefficient: 2
For compound 3 the middle estimate is 0.60 log units above the measured one, and the stated range covers the measured number.
By their numbers in this assay, from the lowest: compound 3; then compound 2; then compound 1.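

With pyridin-4-yl in place of 4-fluorophenyl on an amine nitrogen in a ring, this assay records a number 2.50 log units lower from compound 1 to compound 3 (beyond the scatter) for this single change. The earlier gap spanned more than one change, whereas this large step can be tied to one place and shows that the group on this ring nitrogen alone can move the number far. No measurement here explains why the number moves.

A plain phenyl ring at this place would help separate the loss of the fluorine from the arrival of the ring nitrogen, since both happen together in this change. Pyridin-3-yl would show whether the location of the nitrogen within the ring matters, and it remains open whether the same swap gives a similar step on a different core.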